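A Cyano Group Added to Compound 3

The source may report more compounds than this note shows. Statements on the series, on what has been measured and on what is new or still open speak of the compounds shown alone.

Measured so far in a physicochemical assay for solubility, in phosphate buffer, at pH 7.4; on this read-out higher numbers stand for higher solubility and lower numbers for lower solubility (three compounds):
Compound 1 `Nc1nc(-c2cccc(OC(F)(F)F)c2)cc(=O)[nH]1` gives 330000 nM in this test
Compound 2 `CNc1nc(-c2ccc(OCC(C)C)c(C#N)c2)c(C#N)c(=O)[nH]1` gives 37000 nM in this test
Compound 3 `CC(C)COc1ccc(-c2cc(O)nc(N)n2)cc1` gives 23000 nM in this test

Compound 3 and compound 2 lie within the usual scatter of each other, while compound 1 stands higher, beyond that scatter. Compound 4 `CC(C)COc1ccc(-c2cc(O)nc(N)n2)cc1C#N` is compound 3 with one change (cyano in place of hydrogen on an aromatic carbon, ortho to an isobutoxy group: cyano in place of hydrogen on an aromatic carbon). Among the compounds with values here, no measured pair shows this change alone. Compound 2 also carries cyano and isobutoxy groups, though it differs elsewhere too, and its value (37000 nM) lies within the scatter of compound 3. No step beyond the scatter is therefore expected in this assay. The expected change is small (a 1.1-fold higher number from compound 3 to compound 4 (0.05 log units; within the scatter)) and could go either way. For compound 4 the estimate is 26000 nM, with an expected range from 9000 nM to 75000 nM.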

Compound 4, solubility: 140000 nM
The estimate for compound 4 lay 5.4-fold (0.73 log units) below the measured number; measured number outside the range, above it.
By their numbers in this assay, from the lowest: compounds 3 and 2 (each within the scatter of the next); then compound 4; then compound 1.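

In this assay, cyano in place of hydrogen, ortho to the isobutoxy group, brings a 6.1-fold higher number from compound 3 to compound 4 (0.78 log units; beyond the scatter) as a step beyond the usual scatter. Within the data shown here, this is the first view of the change on its own, since compound 2 carries both groups but differs elsewhere too. No measurement here accounts for the rise. Going by these compounds, whether an amine or a carboxylic acid in the same place would shift the number as well stays open. So does whether cyano would give a similar step on another compound, such as compound 1.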